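Amide aryl variation on the shared core

This account rests on a few compounds, and the source may have more. Where it says the series, first, only, none or still open, it means among the compounds named here.

Measured so far:
compound 1, `O=C(Nc1cccc(-c2oc3cc(-c4ccc(F)cc4)ccc3c(=O)c2O)c1)c1ccccc1F`: 17400 nM
compound 2, `Cc1ccccc1C(=O)Nc1cccc(-c2oc3cc(-c4ccc(F)cc4)ccc3c(=O)c2O)c1`: 24800 nM
compound 3, `O=C(Nc1cccc(-c2oc3cc(-c4ccc(F)cc4)ccc3c(=O)c2O)c1)c1cc(F)cc(F)c1`: 7410 nM

In a functional assay on GTL 16 cells for antiproliferative activity against GTL 16 cell line (Homo sapiens), read by CCK-8 assay, with a stated time of 72 h (a lower number here means a stronger inhibitor, a higher number a weaker inhibitor), compound 1 stands second highest of the three numbers; its nearest neighbour is compound 2, with a 1.4-fold higher number from compound 1 to compound 2 (0.15 log units; within the scatter), and its furthest is compound 3, with a 2.3-fold lower number from compound 1 to compound 3 (0.37 log units; beyond the scatter). Compound 4, `O=C(Nc1cccc(-c2oc3cc(-c4ccc(F)cc4)ccc3c(=O)c2O)c1)c1ccc([N+](=O)[O-])cc1`, is not yet measured. It differs from compound 1 by 4-nitrophenyl in place of 2-fluorophenyl on a carbonyl carbon. Of the measured steps, only a 2.3-fold lower number from compound 1 to compound 3 (0.37 log units; beyond the scatter) and a 3.3-fold lower number from compound 2 to compound 3 (0.52 log units; beyond the scatter) change the group on the carbonyl carbon, and both are modest. Neither places a nitro group there, so the bearing is loose. Compound 4 is therefore expected to give a number near that of compound 1, with a step of a 1.2-fold lower number from compound 1 to compound 4 (0.09 log units; within the scatter), not beyond the scatter. The estimate for compound 4 is 14000 nM, within 5000 nM to 40000 nM.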

Compound 4, half-maximal inhibitory concentration: 18200 nM
For compound 4 the middle estimate is 1.3-fold (0.11 log units) below the measured one; measured number inside the range.
By their numbers in this assay, from the lowest: compound 3; then compounds 1, 4 and 2 (each within the scatter of the next).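

In this assay the 4-nitrophenyl amide sits level with the 2-fluorophenyl amide (a 1.0-fold higher number from compound 1 to compound 4 (0.02 log units; within the scatter)) and with the 2-methylphenyl amide (a 1.4-fold lower number from compound 2 to compound 4 (0.13 log units; within the scatter)), so this position takes a larger group carrying two hydrogen-bond acceptors with no readable shift. Compound 3 remains the only one set apart among the four (a 2.5-fold higher number from compound 3 to compound 4 (0.39 log units; beyond the scatter)). No measurement available here explains this flat response.

From the compounds shown here alone, whether an amine or a carboxylic acid in place of the nitro group would leave the number at this level stays open. So does whether an alkyl chain on the carbonyl carbon, in place of the aromatic ring, would match compound 3.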